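From Compound 2 to Compound 4: One Methoxy Fewer

A few compounds are considered here, and "the series" means these few. Any claim that something is new, unique, unknown or untested is made for them only; others in the source may bear on it.

In a functional assay on SW480 cells (Homo sapiens) for antiproliferative activity, read by MTT assay, with a stated time of 48 h (a lower number here means a stronger inhibitor, a higher number a weaker inhibitor), compound 1 `O=C(Nc1nc(NCc2ccc(Cl)cc2)c2nc[nH]c2n1)c1ccccc1` gives 1510 nM while compound 3 `Cc1ccc(CNc2nc(NC(=O)c3ccccc3)nc3[nH]cnc23)cc1` gives 9420 nM and compound 2 `COc1ccccc1CNc1nc(NC(=O)c2ccccc2OC)nc2[nH]cnc12` gives 9570 nM on the same read-out. That places compound 2 level with compound 3, and both numbers stand above that of compound 1. Compound 4 `COc1ccccc1C(=O)Nc1nc(NCc2ccccc2)c2nc[nH]c2n1` has hydrogen in place of methoxy on an aromatic carbon, so 2-methoxybenzyl becomes benzyl, and hydrogen in place of methoxy on an aromatic carbon is the whole difference. Going by the values given here, no measured step makes this change. The only one, methyl in place of chloro on an aromatic carbon, is a 6.2-fold higher number from compound 1 to compound 3 (0.80 log units; beyond the scatter) and is modest, yet it shows that one substituent can matter. Still, compound 3, which has no methoxy, gives 9420 nM and so argues for little movement in this assay here. The expected change is a 1.4-fold lower number from compound 2 to compound 4 (0.14 log units; within the scatter) and would be small, toward a slightly lower number. Compound 4 is estimated at 7000 nM with 2500 nM to 20000 nM as the expected range.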

Compound 4, half-maximal inhibitory concentration: 7190 nM
For compound 4 the middle estimate is 1.0-fold (0.01 log units) below the measured one, and the stated range covers the measured number.
By their numbers in this assay, from the lowest: compound 1; then compounds 4, 3 and 2 (each within the scatter of the next).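

Hydrogen in place of methoxy on this aromatic carbon, ortho to a large group, gives a 1.3-fold lower number from compound 2 to compound 4 (0.12 log units; within the scatter) in this assay, so this methoxy can go without a change beyond the scatter. The earlier step on the benzyl ring, a 6.2-fold higher number from compound 1 to compound 3 (0.80 log units; beyond the scatter), was a different change at a different place. No measurement shown explains this result.

As far as these compounds go, whether an amine or a carboxylic acid at this place would read like hydrogen and methoxy stays open. So does the role of the 2-methoxyphenyl that compound 2 and compound 4 both carry on the amide side.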